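The source may hold more compounds than are shown below. What is called first, only, known or untested is meant among the compounds shown, and "the series" means these compounds.

Working notes on the series sharing the core of compound 1 `Cc1nc(S(C)(=O)=O)ccc1Oc1ncnc(OC2CCN(C(=O)SC(C)C)CC2)c1F`, which is varied only at the group attached to the carbonyl carbon on the piperidine-type nitrogen. In a functional assay on isolated protein for inhibition of Glucose-dependent insulinotropic receptor (Homo sapiens), read by HTRF and cAMP accumulation (on this read-out lower numbers stand for an effect already at smaller amounts and higher numbers for an effect only at larger amounts of compound), compound 1 gives 6.8 nM, the lowest number of the three measured here. Compound 2 `Cc1nc(S(C)(=O)=O)ccc1Oc1ncnc(OC2CCN(C(=O)C3(F)CCC3)CC2)c1F` carries a four-membered non-aromatic ring of carbon only in that place and in this assay compound 2 gives 24.7 nM; the step is a 3.6-fold higher number from compound 1 to compound 2 (0.56 log units; beyond the scatter). Compound 3 `Cc1nc(S(C)(=O)=O)ccc1Oc1ncnc(OC2CCN(C(=O)c3nc(C(C)(C)F)no3)CC2)c1F` carries a five-membered aromatic ring with 3 hetero atoms there and in this assay compound 3 gives 43.4 nM; the step is a 6.4-fold higher number from compound 1 to compound 3 (0.80 log units; beyond the scatter). Between the two ring-bearing compounds the step is a 1.8-fold higher number from compound 2 to compound 3 (0.24 log units; within the scatter).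

Compound 4 `Cc1nc(S(C)(=O)=O)ccc1Oc1ncnc(OC2CCN(C(=O)c3ncc(Cl)cn3)CC2)c1F` has not yet been measured. Its change from compound 1 is 5-chloropyrimidin-2-yl in place of isopropylsulfanyl on a carbonyl carbon. Both measured steps that exchange the isopropylsulfanyl group for a ring on the carbonyl carbon, a 3.6-fold higher number from compound 1 to compound 2 (0.56 log units; beyond the scatter) and a 6.4-fold higher number from compound 1 to compound 3 (0.80 log units; beyond the scatter), went to higher numbers by a modest amount, and compound 4 makes the same kind of exchange. A higher number than compound 1 is therefore expected, of a size in the range of those two steps; the expected step is a 4.4-fold higher number from compound 1 to compound 4 (0.64 log units; beyond the scatter). In this assay compound 4 is estimated at 30 nM, with a likely range from 12 nM to 80 nM.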

Compound 4, half-maximal effective concentration: 6.12 nM
For compound 4 the middle estimate is 4.9-fold (0.69 log units) above the measured one, outside the stated range (below it).
By their numbers in this assay, from the lowest: compounds 4 and 1 (each within the scatter of the next); then compounds 2 and 3 (each within the scatter of the next).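

In this assay the step of a 1.1-fold lower number from compound 1 to compound 4 (0.05 log units; within the scatter) shows that placing a ring on the carbonyl carbon need not cost anything against isopropylsulfanyl, so the higher numbers of compound 2 and compound 3 do not extend to every ring-bearing group. The identity of the ring-bearing group matters at this position: the step of a 7.1-fold lower number from compound 3 to compound 4 (0.85 log units; beyond the scatter) and the step of a 4.0-fold lower number from compound 2 to compound 4 (0.61 log units; beyond the scatter) both lie beyond the scatter, and an aromatic ring alone does not decide the outcome, as compound 3 and compound 4 each carry one. Nothing available here bears on what sets 5-chloropyrimidin-2-yl apart from the other two ring-bearing groups.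

Open, as far as these compounds go, is how the number would respond to a methoxy group or a nitrile in place of the chlorine of 5-chloropyrimidin-2-yl, or to a phenyl ring on the carbonyl carbon. Also open, from the compounds shown here alone, is what an amine on that carbonyl carbon would give, and whether compound 1 and compound 4 stay level on any read-out other than this assay in these notes.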